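Swapping a methyl for chloro on the anilide ring

The compounds below may be only part of what the source reports. "The series", "measured", "known", "first", "only" and "open" are said of these compounds alone.

Measured so far:
Compound 1, `Cc1ccc(CC(=O)O)cc1NC(=O)c1cc(C)c(OC[C@@H]2CN(C)c3ccccc3O2)cc1C`: 5.7 nM
Compound 2, `Cc1ccc(CC(=O)O)cc1NC(=O)c1c(C)cc(OC[C@@H]2CN(C)c3ccccc3O2)cc1C`: 4.8 nM

In a functional assay on CHO cells for antagonist activity at prostaglandin D2 receptor (Mus musculus), read by cAMP accumulation and immunoassay, with a stated time of 10 min (a lower number here means a stronger inhibitor, a higher number a weaker inhibitor), compound 1 gives 5.7 nM, the higher of the two numbers; compound 2 gives 4.8 nM, and the two values lie within the scatter of each other, so no order between them can be claimed. Compound 3, `Cc1cc(C(=O)Nc2cc(CC(=O)O)ccc2Cl)c(C)cc1OC[C@@H]1CN(C)c2ccccc2O1`, has not yet been measured. It differs from compound 1 by chloro in place of methyl on an aromatic carbon. Among the measured compounds shown here, with no measured step of this kind at hand, the step of a 1.0-fold lower number from compound 1 to compound 3 (0.02 log units; within the scatter) is expected to stay within the scatter in either direction. Compound 3 is therefore estimated at 5.5 nM, with a range from 2 nM to 15 nM.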

Compound 3, half-maximal inhibitory concentration: 5.1 nM
The estimate for compound 3 lay 1.1-fold (0.03 log units) above the measured number, within the range that was stated.
By their numbers in this assay, from the lowest: compounds 2, 3 and 1 (each within the scatter of the next).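

In this assay, chloro can stand in place of methyl on this ring, ortho to a large group, with no change that can be told from scatter: the step is a 1.1-fold lower number from compound 1 to compound 3 (0.05 log units; within the scatter). So this position accepts either of these two groups, which compounds 1 and 2 alone could not show. No available measurement bears on why the two groups read alike.

From the compounds shown here alone, whether a fluoro, a methoxy or a nitrile at this position would read the same stays open. So does whether chloro for methyl would read alike on the core of compound 2.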